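Swapping the pyrrolidine substituent of compound 3 for a cyclopropylsulfonyl

A few compounds are considered here, and "the series" means these few. Any claim that something is new, unique, unknown or untested is made for them only; others in the source may bear on it.

Three compounds share one core and differ only in the group on the pyrrolidine nitrogen. Compound 1 `CN1CCN(c2ccc(Nc3ncc4nc(Nc5ccc(F)cc5)n([C@@H]5CCN(C(=O)OC(C)(C)C)C5)c4n3)cc2)CC1` gives 27 nM in a functional assay on HCC827 cells (Homo sapiens) for antiproliferative activity, read by MTT assay, with a stated time of 72 h; a lower number here means a stronger inhibitor, a higher number a weaker inhibitor. Compound 2 `CCOC(=O)CN1CC[C@H](n2c(Nc3ccc(F)cc3)nc3cnc(Nc4ccc(N5CCN(C)CC5)cc4)nc32)C1` gives 1810 nM, and compound 3 `CN1CCN(c2ccc(Nc3ncc4nc(Nc5ccc(F)cc5)n([C@@H]5CCN(C(=O)CO)C5)c4n3)cc2)CC1` gives 350 nM, placing compound 3 second highest of the three numbers, with compound 2 nearest and compound 1 furthest. The measured steps are a 67-fold higher number from compound 1 to compound 2 (1.83 log units; beyond the scatter), a 13-fold higher number from compound 1 to compound 3 (1.11 log units; beyond the scatter) and a 5.2-fold lower number from compound 2 to compound 3 (0.71 log units; beyond the scatter).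

Compound 4 `CN1CCN(c2ccc(Nc3ncc4nc(Nc5ccc(F)cc5)n([C@H]5CCN(S(=O)(=O)C6CC6)C5)c4n3)cc2)CC1` has not been measured. It differs from compound 3 by 1-(cyclopropylsulfonyl)pyrrolidin-3-yl in place of 1-((hydroxymethyl)carbonyl)pyrrolidin-3-yl on an aromatic nitrogen. Within the data shown here, the steps that bear on this change are those from compound 1 to compound 3 and from compound 1 to compound 2: both show that the group on this pyrrolidine nitrogen moves the number by a large amount, and the tert-butoxycarbonyl of compound 1 gave the lowest value. The cyclopropylsulfonyl has no hydrogen-bond donor, as the tert-butoxycarbonyl has none, so compound 4 is expected to give a lower number than compound 3, a 3.9-fold lower number from compound 3 to compound 4 (0.59 log units; beyond the scatter). Compound 4 is estimated at 90 nM, in the range 25 nM to 350 nM.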

Compound 4, half-maximal inhibitory concentration: 7.5 nM
Compound 4: the middle estimate sits 12-fold (1.08 log units) above what was measured; the measured number lies below the stated range.
By their numbers in this assay, from the lowest: compound 4; then compound 1; then compound 3; then compound 2.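

With the cyclopropylsulfonyl group on the pyrrolidine nitrogen, this assay shows a 47-fold lower number from compound 3 to compound 4 (1.67 log units; beyond the scatter), and the replacement of (ethoxycarbonyl)methyl by this group gives a 240-fold lower number from compound 2 to compound 4 (2.38 log units; beyond the scatter). Among these compounds, the tert-butoxycarbonyl group, until now the one with the lowest number, is also passed, with a 3.6-fold lower number from compound 1 to compound 4 (0.56 log units; beyond the scatter), which makes compound 4 the strongest inhibitor of the four. A carbonyl directly on this nitrogen is therefore not needed for a low number, since a sulfonyl in that place does better than all three earlier groups.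

Nothing available here explains this order. From the compounds shown here alone, it also remains open whether the cyclopropyl ring or the sulfonyl carries the gain, which a methylsulfonyl group and a cyclopropylcarbonyl group on the same nitrogen could separate.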